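Series notes: from compound 2 to compound 3

A few compounds are considered here, and "the series" means these few. Any claim that something is new, unique, unknown or untested is made for them only; others in the source may bear on it.

Measured so far:
compound 1, `CC(C)(C)c1cc(/C=C/C(=O)NCC2CCN(Cc3ccccc3)CC2)cc(C(C)(C)C)c1O` — 11700 nM
compound 2, `COc1ccc(CN2CCC(CCNC(=O)/C=C/c3cc(C(C)(C)C)c(O)c(C(C)(C)C)c3)CC2)cc1` — 6700 nM

Both numbers come from an assay on isolated protein for inhibition of Amine oxidase [flavin-containing] B (Homo sapiens), read by fluorescence, with stated times of 15 min and 20 min; a higher number here means a weaker inhibitor, a lower number a stronger inhibitor. On these two values compound 2 gives the smaller number and compound 1 the larger, but the gap between them lies within the scatter and does not separate the two compounds. Compound 1 and compound 2 differ in more than one place, so no single structural step can be read from their pair.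

Compound 3, `CC(C)(C)c1cc(/C=C/C(=O)NCCC2CCN(Cc3ccccc3F)CC2)cc(C(C)(C)C)c1O`, is not yet measured. It differs from compound 2 in one place only: 2-fluorophenyl in place of 4-methoxyphenyl on a saturated chain carbon bound to an amine nitrogen in a ring. Among the compounds with values here, no measured pair shows this change, so there is nothing to scale it against. The expectation for compound 3 in this assay is a step of a 1.2-fold higher number from compound 2 to compound 3 (0.08 log units; within the scatter) that stays within the scatter, with no clear direction. Compound 3 is estimated at 8000 nM, with a range from 3000 nM to 22000 nM.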

Compound 3, half-maximal inhibitory concentration: 7400 nM
Compound 3: middle estimate off by 1.1-fold (0.03 log units), on the high side; measured number inside the range.
By their numbers in this assay, from the lowest: compounds 2, 3 and 1 (each within the scatter of the next).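

In this assay, 2-fluorophenyl in place of 4-methoxyphenyl on a saturated chain carbon bound to an amine nitrogen in a ring gives a 1.1-fold higher number from compound 2 to compound 3 (0.04 log units; within the scatter). Within the data shown here, this is the first single-place step, and it does not separate the two groups: at this position, 4-methoxybenzyl and 2-fluorobenzyl read alike within the scatter. No supporting data bear on this result.

Compound 1 differs from compound 2 and from compound 3 in more than one place, so the effect of the linking chain alone remains unread, as does whether the same exchange would read alike on the chain of compound 1. Also open, on these data alone, is how this position would respond to a group of another kind, such as a pyridine ring or a phenyl ring carrying a carboxylic acid.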